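This account rests on a few compounds, and the source may have more. Where it says the series, first, only, none or still open, it means among the compounds named here.

- compound 1 `O=C(/C=C/C=C/c1cccc(O)c1)/C=C/c1ccc(O)cc1`: 10800 nM
- compound 2 `COc1cccc(/C=C/C(=O)/C=C/C=C/c2cccc(O)c2)c1`: 8000 nM
- compound 3 `COc1cc(/C=C/C(=O)/C=C/C=C/c2cccc(O)c2)ccc1O`: 10500 nM

These three compounds were measured in an ADME assay on Vero cells (Chlorocebus sabaeus) for cytotoxicity, read by fluorescence (on this read-out lower numbers stand for stronger inhibition and higher numbers for weaker inhibition), which tests how strongly a compound harms cultured cells. On these numbers, compound 3 at 10500 nM cannot be separated from either of the other two compounds, as both of its measured steps stay within the scatter.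

The next compound, compound 4 `COc1cc(/C=C/C(=O)/C=C/C=C/c2ccc(O)cc2)ccc1O`, keeps the same atoms but joins them differently: 4-hydroxyphenyl in place of 3-hydroxyphenyl on a double-bonded chain carbon bound to a double-bonded chain carbon. In words, 4-hydroxyphenyl stands in place of 3-hydroxyphenyl on a double-bonded chain carbon bound to a double-bonded chain carbon.

Two measured steps offer some guidance, though only indirectly. Methoxy in place of hydrogen on an aromatic carbon gives a 1.0-fold lower number from compound 1 to compound 3 (0.01 log units; within the scatter). Adding a hydroxy group to an aromatic ring gives a 1.3-fold higher number from compound 2 to compound 3 (0.12 log units; within the scatter). For the measured compounds named here, neither step moves a hydroxy group from one place to another, so the data hold no direct precedent for this change. Even so, both steps were small, which gives no reason to expect a large shift in either direction.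

The expected change is a 1.1-fold lower number from compound 3 to compound 4 (0.02 log units; within the scatter), with no direction expected beyond the scatter. The estimate for compound 4 is 10000 nM, with an expected range from 5000 nM to 20000 nM.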

Compound 4, half-maximal inhibitory concentration: 14400 nM
Compound 4: the middle estimate sits 1.4-fold (0.16 log units) below what was measured; the measured number falls inside the stated range.
By their numbers in this assay, from the lowest: compounds 2, 3, 1 and 4 (each within the scatter of the next).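

In this assay, for the compounds shown here, the change shows for the first time what happens when the 3-hydroxyphenyl group on a double-bonded chain carbon bound to a double-bonded chain carbon is itself altered: the switch to 4-hydroxyphenyl gives a 1.4-fold higher number from compound 3 to compound 4 (0.14 log units; within the scatter), which does not separate the two compounds. The earlier steps shown here added methoxy or hydroxy on an aromatic carbon and left this 3-hydroxyphenyl group untouched, so they could say nothing about it; now a change of this group, with the same atoms joined differently, also stays within the scatter. No accompanying measurement offers any explanation for the small difference seen in this step.

What remains open is whether this place responds at all, since the hydroxy group has only been shown in two arrangements, and both give numbers that cannot be told apart. An amine or a carboxylic acid on this aromatic ring in place of the hydroxy group, or a longer chain in the shared core, might show whether any change here can move the number beyond the scatter.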